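A few compounds are considered here, and "the series" means these few. Any claim that something is new, unique, unknown or untested is made for them only; others in the source may bear on it.

Three compounds share one core and were compared in an assay on cells for antagonist activity at transient receptor potential cation channel subfamily V member 1 (Homo sapiens), read by FLIPR and calcium flux, with a stated time of 6 min; on this read-out higher numbers stand for weaker inhibition and lower numbers for stronger inhibition. There compound 1 `CC(C(=O)NCc1ccc(C(C)(C)C)nc1N1CCC(Cc2ccccc2)CC1)c1ccc(NS(C)(=O)=O)c(F)c1` gives 0.3 nM, compound 2 `CC(C(=O)NCc1ccc(C(C)(C)C)nc1OCc1ccccc1)c1ccc(NS(C)(=O)=O)c(F)c1` gives 4.4 nM, and compound 3 `CC(C(=O)NCc1ccc(C(C)(C)C)cc1N1CCCC1)c1ccc(NS(C)(=O)=O)c(F)c1` gives 8.1 nM. Compound 3 thus carries the highest number of the three; its value and that of compound 2 lie within the usual scatter of each other, whereas compound 1 sits far below it, beyond the scatter. Compound 4 `CC(C)CCOc1cc(C(C)(C)C)ccc1CNC(=O)C(C)c1ccc(NS(C)(=O)=O)c(F)c1` differs from compound 3 in a single place: isopentyloxy in place of pyrrolidin-1-yl on an aromatic carbon. Going by the values given here, no measured pair shows a change of this kind, so the expectation rests on compound 3 alone. Only a modest step is expected, a 1.4-fold lower number from compound 3 to compound 4 (0.13 log units; within the scatter), not clearly beyond the scatter in either direction. Compound 4 is therefore expected to give 6 nM, with a likely range from 2 nM to 20 nM.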

Compound 4, inhibition constant: 0.6 nM
Beside the measured number, compound 4's estimate is 10-fold (1.00 log units) above it; the measured number lies below the stated range.
By their numbers in this assay, from the lowest: compounds 1 and 4 (each within the scatter of the next); then compounds 2 and 3 (each within the scatter of the next).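

On this aromatic carbon, ortho to a large group, isopentyloxy in place of pyrrolidin-1-yl gives a 14-fold lower number from compound 3 to compound 4 (1.13 log units; beyond the scatter) in this assay and so shows that the group held here can strongly change the read-out. The earlier compounds shown here differ in more than one place and could not show this. No measurement given here explains the size of this step.

Going by these compounds, two things change at once, the ring opens into a chain and nitrogen gives way to oxygen, so their shares remain open. An isopentylamino group, with the same chain joined through nitrogen, or a shorter ethoxy group would help to separate them.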